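Restoring a Hydroxyphenyl Group After a Pyridine Dead End

The compounds below may be only part of what the source reports. "The series", "measured", "known", "first", "only" and "open" are said of these compounds alone.

Compound 3 `Cc1c(C(=O)N/N=C\c2ccncc2)oc2cccc(O)c12` carries a pyridin-4-yl on the carbon with a double bond to nitrogen. In a functional assay on PC-3 cells (Homo sapiens) for inhibition (on this read-out higher numbers stand for weaker inhibition and lower numbers for stronger inhibition), compound 3 gives only a limit of >= 40000 nM and no number. Compound 2 `Cc1c(C(=O)N/N=C\c2ccco2)oc2cccc(O)c12` likewise reaches only a limit of >= 40000 nM in this assay. Compound 1 `Cc1ccc(O)c(/C=N\NC(=O)c2oc3cccc(O)c3c2C)c1` gives 7350 nM in this assay, so that an at least 5.4-fold higher number from compound 1 to compound 3 (0.73 log units; beyond the scatter) and an at least 5.4-fold higher number from compound 1 to compound 2 (0.73 log units; beyond the scatter), whereas a step that the two limits leave unreadable from compound 2 to compound 3. The change to compound 4 `Cc1c(C(=O)N/N=C\c2cccc(Br)c2O)oc2cccc(O)c12` is 3-bromo-2-hydroxyphenyl in place of pyridin-4-yl on a carbon with a double bond to nitrogen. Because compound 1 with its hydroxyphenyl sat at 7350 nM and its removal gave an at least 5.4-fold higher number from compound 1 to compound 3 (0.73 log units; beyond the scatter), bringing back a hydroxyphenyl is expected to return the number roughly to that level. Compound 4 is therefore estimated at 8000 nM with a range from 3000 nM to 30000 nM, which corresponds to an at least 5.0-fold lower number from compound 3 to compound 4 (0.69 log units; beyond the scatter).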

Compound 4, half-maximal inhibitory concentration: 16600 nM
Compound 4: the middle estimate sits 2.1-fold (0.32 log units) below what was measured; measured number inside the range.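

In this assay, 3-bromo-2-hydroxyphenyl on the carbon with a double bond to nitrogen brings back a measurable inhibition, giving an at least 2.4-fold lower number from compound 3 to compound 4 (0.38 log units; beyond the scatter) and an at least 2.4-fold lower number from compound 2 to compound 4 (0.38 log units; beyond the scatter). Compound 2 and compound 3 each stop at a limit and not a number: the limit of >= 40000 nM in this assay, at which 2 of the 4 values shown sit. The two hydroxyphenyl groups shown are not interchangeable, with a 2.3-fold higher number from compound 1 to compound 4 (0.35 log units; beyond the scatter).

The compounds shown leave open whether the hydroxyl or the bromine accounts for the gain. They also leave open how an unsubstituted 2-hydroxyphenyl, or one carrying an amine instead of the bromine, would read out.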